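One Double Bond, Drawn Without a Configuration

The source may hold more compounds than are shown below. What is called first, only, known or untested is meant among the compounds shown, and "the series" means these compounds.

For the measured compounds named here, in a functional assay on U-87MG ATCC cells (Homo sapiens) for cytotoxicity, read by MTT assay, with a stated time of 48 h (a lower number here means a stronger inhibitor, a higher number a weaker inhibitor), compound 3 `C/C(=N/NC(=S)Nc1ccccc1I)c1ccccn1` gives 6.1 nM and stands level with compound 1 `C/C(=N\NC(=S)Nc1ccccc1I)c1ccccn1` at 6.1 nM on the numbers so far. Compound 2 `CC(=NNC(=S)Nc1ccccc1F)c1ccccn1` gives 5 nM and its gap to compound 3 lies within the scatter of repeated measurements, so these three cannot be ranked.

Compound 4 `CC(=NNC(=S)Nc1ccccc1I)c1ccccn1` has not yet been measured. Against compound 3 the whole difference is the two compounds have the same atoms and bonds; at least one stereo element is drawn with a configuration in one of them and without one in the other: 1 of 1 stereo elements differ; a double bond is drawn Z in compound 3 and without a configuration in compound 4 and nothing else, so no group leaves or enters.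

Going by the values given here, the one measured step that bears on this concerns the same double bond, drawn E in compound 1 and Z in compound 3. It shows no change at the digits printed from compound 1 to compound 3 (within the scatter) with the fact that compounds 1 and 3 differ only in the configuration as drawn as the basis for the comparison. Both drawn forms read alike, so leaving the configuration undrawn gives no reason to expect a shift in either direction in this assay for the new compound.

The step expected is no change at the digits printed from compound 3 to compound 4 (within the scatter) and so none beyond the scatter. For compound 4 the estimated value is 6.1 nM with an expected range from 4.3 nM to 8.6 nM as the likely span.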

Compound 4, half-maximal inhibitory concentration: 6.1 nM
For compound 4 middle estimate and measured number coincide at the digits printed, and the stated range covers the measured number.
By their numbers in this assay, from the lowest: compounds 2, 1, 3 and 4 (each within the scatter of the next).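

In this assay, the undrawn form of this double bond now reads the same as both drawn forms: no change at the digits printed from compound 3 to compound 4 (within the scatter), and no change at the digits printed from compound 1 to compound 4 (within the scatter). The earlier compounds compared only the two drawn forms, so this is the first evidence that leaving the configuration unstated makes no readable difference among these compounds, and the only thing separating the pair is how the double bond is drawn: the fact that one of compounds 3 and 4 is drawn with a defined configuration and the other without, at the place where they differ Compound 4 also gives compound 2 a partner that differs in one place only, and this swap of iodo for fluoro on an aromatic carbon stays within the scatter too, with a 1.2-fold higher number from compound 2 to compound 4 (0.09 log units; within the scatter).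

With only fluoro and iodo shown at this place, it remains open whether a very different group, such as an amine or a carboxylic acid, would leave the number where it stands. An undrawn double bond also does not state which form or mixture of forms the sample contained, so the agreement among these numbers cannot say whether the two configurations would stay level in another cell line.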